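An amide-linked triazole variant of compound 2

The source may hold more compounds than are shown below. What is called first, only, known or untested is meant among the compounds shown, and "the series" means these compounds.

Three compounds of the shared core were measured in a functional assay on DU-145 cells (Homo sapiens) for inhibition, read by MTT assay, with a stated time of 24 h; a higher number here means a weaker inhibitor, a lower number a stronger inhibitor:
- compound 1 `Cc1ccc(-c2cc(COC3(C(F)(F)F)Oc4ccccc4C=C3C(=O)O)on2)cc1`: 41400 nM
- compound 2 `CCOC(=O)C1=Cc2ccccc2OC1(OCc1cn(-c2ccccc2)nn1)C(F)(F)F`: > 150000 nM
- compound 3 `CCOC(=O)C1=Cc2ccccc2OC1(OCc1cc(-c2cccc(C(F)(F)F)c2)no1)C(F)(F)F`: 57300 nM

Compound 1 and compound 3 give numbers, both weak. Compound 2 is different: for compound 2 the assay returns only a limit, > 150000 nM, and no number; this is the limit of > 150000 nM in this assay, at which 1 of the 3 values shown sits. Compound 2 therefore stands at the floor of what was resolved, and whether it is weaker than compound 1 and compound 3 by little or by much is not known.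

Compound 4 `CCOC(=O)C1=Cc2ccccc2OC1(OCc1cn(CC(=O)Nc2cccc(F)c2)nn1)C(F)(F)F` has not yet been measured. It differs from compound 2 in one place: ((3-fluorophenyl)carbamoyl)methyl in place of phenyl on an aromatic nitrogen. Within the data shown here, no measured pair shows a change of this kind, so there is no step in this assay to lean on. The expectation for the step from compound 2 to compound 4 is therefore a modest one, an at least 1.5-fold lower number from compound 2 to compound 4 (0.17 log units; that floor lies within the scatter), leaning toward a slightly stronger inhibitor but not with confidence beyond the scatter. Compound 4 is estimated at 100000 nM, within 30000 nM to 300000 nM, and a limit rather than a number remains a real possibility.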

Compound 4, half-maximal inhibitory concentration: > 150000 nM
Compound 4 ended at the assay's limit; the forecaster's own chance of this, stated with the estimate: 45%; at least 1.5-fold (0.17 log units) between middle value and limit.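

Compound 2 and compound 4 both end at a limit and give no number, so no step can be read between them: the limit of > 150000 nM in this assay, at which 2 of the 4 values shown sit.

Going by these compounds, whether ((3-fluorophenyl)carbamoyl)methyl in place of phenyl on an aromatic nitrogen changes inhibition at all, and in which direction, remains open.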